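Bromo in Place of Methyl: Expectation for Compound 4

The compounds below may be only part of what the source reports. "The series", "measured", "known", "first", "only" and "open" are said of these compounds alone.

Three compounds sharing one core were tested in a functional assay on MCF7 cells (Homo sapiens) for antiproliferative activity, read by MTT assay, with a stated time of 72 h; a higher number here means a weaker inhibitor, a lower number a stronger inhibitor:

compound 1 `CCCSc1nc(N/N=C/c2ccc(C)cc2)c2nnn(Cc3ccccc3)c2n1`, > 64000 nM, a limit of the assay
compound 2 `C#CCSc1nc(N/N=C/c2ccc(N(C)C)cc2)c2nnn(Cc3ccccc3)c2n1`, > 64000 nM, a limit of the assay
compound 3 `CCCSc1nc(N/N=C/c2cc(OC)c(OC)c(OC)c2)c2nnn(Cc3ccccc3)c2n1`, > 64000 nM, a limit of the assay

Compound 1 stands at the limit of this assay, where no number was obtained. The same is true of compound 2 and of compound 3, so that the whole picture is the limit of > 64000 nM in this assay, at which 3 of the 3 values shown sit. For the measured compounds named here, no pair of measured compounds differs in a single place, and no measured step is available to set the size of any change.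

Compound 4 `CCCSc1nc(N/N=C/c2ccc(Br)cc2)c2nnn(Cc3ccccc3)c2n1` is the one still untested. It differs from compound 1 by bromo in place of methyl on an aromatic carbon. With every value in this assay sitting at the limit, the change from compound 1 is expected to produce no step beyond the scatter, that is a step that the limit leaves unreadable from compound 1 to compound 4. Compound 4 is therefore expected to give about 90000 nM in this assay, within a range from 20000 nM to 400000 nM, most likely again reported only as a limit.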

Compound 4, half-maximal inhibitory concentration: > 64000 nM
Compound 4: no number, only a limit (the forecaster's own chance of this, stated with the estimate: 85%); the middle value does not contradict the limit.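

Compound 1 and compound 4 both give only a limit in this assay, so no step can be read between them: the limit of > 64000 nM in this assay, at which 4 of the 4 values shown sit.

The compounds shown leave open whether any change on the shared core would yield a measurable value in this assay, and how bromo and methyl would then compare.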